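This account rests on a few compounds, and the source may have more. Where it says the series, first, only, none or still open, it means among the compounds named here.

Working notes on the series. Going by the values given here, in an ADME assay on HaCaT cells (Homo sapiens) for cytotoxicity, read by MTT assay, with a stated time of 72 h (on this read-out lower numbers stand for stronger inhibition and higher numbers for weaker inhibition), compound 1 `CC(C)(C)C1=CC(=O)C=CC1=O` gives 95000 nM, the higher of the two numbers so far, and compound 2 `CCNC1=CC(=O)C=C(C(C)(C)C)C1=O` gives 30000 nM. The next structure is compound 3 `CNC1=CC(=O)C(C(C)(C)C)=CC1=O`, which has methylamino in place of hydrogen on a double-bonded ring carbon of the core of compound 1: methylamino in place of hydrogen on a double-bonded ring carbon. Among the compounds with values here, only one measured step bears on this change: a 3.2-fold lower number from compound 1 to compound 2 (0.50 log units; beyond the scatter), a modest step that brings in ethylamino in place of hydrogen on a double-bonded ring carbon. Within the data shown here, no measured step has methylamino, or any amino group three ring bonds from the ring atom that bears the tert-butyl group, so the transfer is uncertain. A lower number of similar size is expected in this assay. The estimated change is a 2.7-fold lower number from compound 1 to compound 3 (0.43 log units; beyond the scatter). For compound 3 the expected value is 35000 nM, with an estimated range of 12000 nM to 85000 nM.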

Compound 3, half-maximal inhibitory concentration: 28000 nM
Estimate against measurement, compound 3: 1.3-fold (0.10 log units) above, and the stated range covers the measured number.
By their numbers in this assay, from the lowest: compounds 3 and 2 (each within the scatter of the next); then compound 1.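

In this assay, methylamino in place of hydrogen on a double-bonded ring carbon, three ring bonds from the ring atom that bears a tert-butyl group, gives a 3.4-fold lower number from compound 1 to compound 3 (0.53 log units; beyond the scatter). A lower number beyond the scatter is therefore now seen at this place as well, with methylamino as the entering group, and the step no longer rests on the ethylamino of compound 2 alone. No measured evidence bears on the reason for this step.

Compound 2 and compound 3 differ both in the amino group and in its place on the ring, so this pair does not separate the two changes. Also open, on these data alone, is how a dimethylamino group, a hydroxyl group or a longer chain such as butylamino would read at this place.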